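Swapping the aryl group on a triazole for hydroxymethyl

The source may report more compounds than this note shows. Statements on the series, on what has been measured and on what is new or still open speak of the compounds shown alone.

Measured compounds in an ADME assay on HeLa cells (Homo sapiens) for cytotoxicity, read by sulforhodamine B assay, with a stated time of 48 h, tested at 10 uM; a higher number here means more inhibition at the concentration tested (going by the name of the read-out), a lower number less inhibition:
- compound 1, `COc1nc2ccc(Br)cc2cc1C(c1ccccc1)n1cc(-c2ccccc2F)nn1`: 14.1%
- compound 2, `CCCCCCCCc1cn(C(c2ccccc2)c2cc3cc(Br)ccc3nc2OC)nn1`: 0.1%
- compound 3, `CCOC(=O)c1cn(C(c2ccccc2)c2cc3cc(Br)ccc3nc2OC)nn1`: -3.67%

Compound 1 stands highest of the three numbers. Its nearest neighbour is compound 2, reached by a drop of a number 14 percentage points lower from compound 1 to compound 2 (beyond the scatter), and the furthest is compound 3, reached by a drop of a number 17.8 percentage points lower from compound 1 to compound 3 (beyond the scatter). Between compound 2 and compound 3 the step is a number 3.8 percentage points lower from compound 2 to compound 3 (within the scatter), so these two cannot be told apart.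

The unmeasured compound 4, `COc1nc2ccc(Br)cc2cc1C(c1ccccc1)n1cc(CO)nn1`, differs from compound 1 in one place: hydroxymethyl in place of 2-fluorophenyl on an aromatic carbon. The two measured steps that bear on this change are the two that also remove the 2-fluorophenyl from the same aromatic carbon of compound 1; both lowered the read-out by a modest amount beyond the scatter, whether the entering group was octyl or ethoxycarbonyl. Hydroxymethyl is a third, smaller entering group, and no measured step says how it behaves on its own, so the expectation rests on the two removals alone.

Compound 4 is therefore expected to lie below compound 1 by roughly a number 12.1 percentage points lower from compound 1 to compound 4 (beyond the scatter), in the region of compound 2 and compound 3. The estimate for compound 4 is 2%, with a range from -8% to 12%.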

Compound 4, a percentage reported as inhibition, at one concentration (the size of the read-out at that concentration, not a potency): 0.25%
The estimate for compound 4 lay 1.8 percentage points above the measured number; low and high end bracket the measured number.
By their numbers in this assay, from the lowest: compounds 3, 2 and 4 (each within the scatter of the next); then compound 1.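

In this assay, hydroxymethyl joins octyl and ethoxycarbonyl as a third group that gives a lower number than 2-fluorophenyl on this aromatic carbon of the five-membered ring, with a number 13.9 percentage points lower from compound 1 to compound 4 (beyond the scatter). Hydroxymethyl has only 2 heavy atoms and brings a hydrogen-bond donor, yet it cannot be told apart from the other two groups, with a number 3.9 percentage points higher from compound 3 to compound 4 (within the scatter) and a number 0.2 percentage points higher from compound 2 to compound 4 (within the scatter). Among these four compounds, then, only the one with an aromatic ring on this carbon stands clear of the rest, although nothing available here explains that difference.

Going by these compounds, it remains open whether the six-membered aromatic ring or its fluorine accounts for the higher number, a question that plain phenyl at this position would address, and whether a pyridine ring would behave like either of them. On these data alone, it is also open whether an aminomethyl group or a carboxylic acid would stay level with compound 4 or move away from it, and any such reading would start from a modest value, since even compound 1 gives only 14.1%.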